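The source may hold more compounds than are shown below. What is called first, only, known or untested is meant among the compounds shown, and "the series" means these compounds.

Compound 1, `Clc1ccccc1CSc1nnc(-c2ccncc2)n1-c1ccccc1`: 18100 nM
Compound 2, `O=C(CSc1nnc(-c2ccncc2)n1-c1ccccc1)N/N=C/c1ccccc1`: 23600 nM

Both compounds were tested in a functional assay on MCF7 cells (Homo sapiens) for inhibition, read by MTT assay, with a stated time of 48 h; on this read-out lower numbers stand for stronger inhibition and higher numbers for weaker inhibition. Compound 2 gives 23600 nM in this assay, the larger of the two numbers, but compound 1 with 18100 nM is so close that the gap is within the scatter, and the two are read as alike. Neither compound is therefore a strong inhibitor on this read-out.

Compound 3, `O=C(CSc1nnc(-c2ccncc2)n1-c1ccccc1)N/N=C/c1cc(Br)ccc1O`, is the next compound to be measured. It differs from compound 2 in one place: 5-bromo-2-hydroxyphenyl in place of phenyl on a carbon with a double bond to nitrogen. Among the compounds with values here, no pair of measured compounds shows a change of this kind, so there is no measured step to lean on, and the two measured compounds, which differ in a different part of the molecule, offer no guide. The expectation is a step from compound 2 to compound 3 of a 1.7-fold lower number from compound 2 to compound 3 (0.23 log units; within the scatter), towards a somewhat lower number, with a range wide enough to include no change beyond the scatter. Compound 3 is estimated to give 14000 nM in this assay, expected to lie between 4500 nM and 45000 nM.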

Compound 3, half-maximal inhibitory concentration: 6460 nM
The estimate for compound 3 lay 2.2-fold (0.34 log units) above the measured number, within the range that was stated.
By their numbers in this assay, from the lowest: compound 3; then compounds 1 and 2 (each within the scatter of the next).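

In this assay, the group on the carbon with a double bond to nitrogen turns out to matter: replacing phenyl with 5-bromo-2-hydroxyphenyl gives a 3.7-fold lower number from compound 2 to compound 3 (0.56 log units; beyond the scatter). Within the data shown here, the first two compounds could not show this, as they differ from each other in more than one place and their numbers lie within the scatter, so this is the first change in a single place whose effect can be read and the first sign that this part of the molecule can alter the read-out, although the step is modest and rests on one pair of compounds. Nothing measured here explains why the number falls, so the step records only what happened and not how it came about.

The bromine and the hydroxyl enter together as one group, so the compounds shown cannot divide the step between them, and it stays open whether either one alone would give a similar change. Also open, from the compounds shown here alone, is how the number would respond to other groups on this ring, such as an amine, a methoxy group or a carboxylic acid.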